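The source may hold more compounds than are shown below. What is called first, only, known or untested is meant among the compounds shown, and "the series" means these compounds.

Within the data shown here, compound 2 `Fc1ccc(C(SCCNC2CCN(Cc3cc4ccccc4[nH]3)CC2)c2ccc(F)cc2)cc1` gives 205 nM in an assay on membranes from Cortex for displacement of a labelled ligand from Sigma non-opioid intracellular receptor 1 (Cavia porcellus), read by scintillation counting, with a stated time of 120 min (a lower number here means a stronger inhibitor, a higher number a weaker inhibitor), the higher of the two numbers so far; its nearest neighbour, compound 1 `O=C(c1ccc(F)cc1)N1CCC(NCCSC(c2ccc(F)cc2)c2ccc(F)cc2)CC1`, gives 32.1 nM. Among the measured compounds shown here, the only measured step, a 6.4-fold higher number from compound 1 to compound 2 (0.81 log units; beyond the scatter), concerns a different part of the molecule. For the measured compounds named here, compound 3 `Fc1ccc(C(SCCNC2CCN(Cc3cc4ccccc4o3)CC2)c2ccc(F)cc2)cc1` differs from compound 2 by 1-benzofuran-2-yl in place of 1H-indol-2-yl on a saturated chain carbon bound to an amine nitrogen in a ring, a swap on which no measured step bears. With nothing to point either way, a step of a 1.2-fold higher number from compound 2 to compound 3 (0.09 log units; within the scatter) that stays within the usual scatter is expected. Compound 3 is therefore estimated at 250 nM, with a range from 100 nM to 650 nM.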

Compound 3, inhibition constant: 205 nM
For compound 3 the middle estimate is 1.2-fold (0.09 log units) above the measured one; the measured number falls inside the stated range.
By their numbers in this assay, from the lowest: compound 1; then compounds 2 and 3 (each within the scatter of the next).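

In this assay, 1-benzofuran-2-yl in place of 1H-indol-2-yl gives no change at the digits printed from compound 2 to compound 3 (within the scatter), so at this position, swapping a hydrogen-bond donor for a hydrogen-bond acceptor leaves the number within the scatter. (1-Benzofuran-2-yl)methyl in place of (4-fluorophenyl)carbonyl gives a 6.4-fold higher number from compound 1 to compound 3 (0.81 log units; beyond the scatter), so the gap from compound 1 remains with the donor of compound 2 gone. Going by these compounds, whether a single ring, such as a plain phenyl or a thiophene, would give a similar number in this place stays open. Nothing here explains why either step has the size it has.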